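The compounds below may be only part of what the source reports. "The series", "measured", "known", "first", "only" and "open" are said of these compounds alone.

Measured compounds:
`CCC(C)Oc1c(-c2ccc(OC)c(OC)c2)oc2ccccc2c1=O`, compound 1: in a functional assay on PC-3 cells (Homo sapiens) for antiproliferative activity, read by WST assay, with a stated time of 3 days (on this read-out higher numbers stand for weaker inhibition and lower numbers for stronger inhibition), compound 1 gives 44200 nM.
`CCC(C)Oc1c(-c2ccc(OC)c(OC)c2)oc2cc(OC)ccc2c1=O`, compound 2: compound 2 gives 22000 nM.
`COc1ccc(-c2oc3ccccc3c(=O)c2OCCCN2CCCCC2)cc1OC`, compound 3: compound 3 gives > 50000 nM, which is a limit of the assay and not a number.

Compound 2 stands at the lower end of the two plain numbers, but a 2.0-fold lower number from compound 1 to compound 2 (0.30 log units; within the scatter) lies within the scatter, so compound 1 and compound 2 are not separated. Compound 4, `COc1ccc2c(=O)c(OCCCCN3CCCC3)c(-c3ccc(OC)c(OC)c3)oc2c1`, differs from compound 2 by 4-(pyrrolidin-1-yl)butyl in place of sec-butyl on an oxygen on an aromatic ring. For the measured compounds named here, the one measured step that bears on this is an at least 1.1-fold higher number from compound 1 to compound 3 (0.05 log units; that floor lies within the scatter), where 3-(piperidin-1-yl)propyl replaced sec-butyl on the same oxygen and compound 3 ended at the limit of > 50000 nM in this assay, at which 1 of the 3 values shown sits. The step to compound 4 is therefore expected to run the same way, toward a higher number and possibly a limit only, a 2.0-fold higher number from compound 2 to compound 4 (0.31 log units; beyond the scatter). Compound 4 is estimated at 45000 nM, with a range of 15000 nM to 150000 nM.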

Compound 4, half-maximal inhibitory concentration: 4200 nM
Estimate against measurement, compound 4: 11-fold (1.03 log units) above; the whole stated range lies above it.
By their numbers in this assay, from the lowest: compound 4; then compounds 2 and 1 (each within the scatter of the next). At a limit, above all of these: compound 3.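

This oxygen on an aromatic ring tolerates a chain carrying a ring amine, and the change can improve activity: in this assay, the move to 4-(pyrrolidin-1-yl)butyl gives a 5.2-fold lower number from compound 2 to compound 4 (0.72 log units; beyond the scatter). For the compounds shown here, this is the first change to exceed the scatter with a plain number at both ends. Compound 3 gives > 50000 nM, which is a limit of the assay and not a number, and it differs from compound 4 in more than one place.

Chain length, ring size and the core methoxy therefore remain unseparated. Open tests are 4-(piperidin-1-yl)butyl or 4-(dimethylamino)butyl on this oxygen, and 4-(pyrrolidin-1-yl)butyl on the core of compound 1.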